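Methoxy in Place of Methyl: Expected Solubility of Compound 4

The compounds below may be only part of what the source reports. "The series", "measured", "known", "first", "only" and "open" are said of these compounds alone.

Compound 1 `CC(C)Nc1nc(NCc2ccco2)c2ccccc2n1` gives in a physicochemical assay for solubility, at pH 2 (a higher number here means a more soluble compound, a lower number a less soluble compound), only a limit, >= 30000 nM.
Compound 2 `CC(C)Nc1nc(NCc2ccco2)c2cccc(Cl)c2n1` gives in this assay a limit too, >= 30000 nM.
Compound 3 `Cc1cccc2c(NCc3ccco3)nc(NC(C)C)nc12` likewise gives in this assay a limit, >= 30000 nM.

Compound 3 therefore stands at the same limit as the other two, a point summed up by the limit of >= 30000 nM in this assay, at which 3 of the 3 values shown sit. The changes among them yield nothing readable: a step that the two limits leave unreadable from compound 1 to compound 2, a step that the two limits leave unreadable from compound 1 to compound 3 and a step that the two limits leave unreadable from compound 2 to compound 3.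

Compound 4 `COc1cccc2c(NCc3ccco3)nc(NC(C)C)nc12` differs from compound 3 by one change: methoxy in place of methyl on an aromatic carbon. Among the measured compounds shown here, no measured step bears on it, so its size cannot be taken from the data. Compound 4 is expected to sit at the same limit, with a step that the limit leaves unreadable from compound 3 to compound 4 estimated as no step beyond the scatter. The estimate for compound 4 is 40000 nM, within 15000 nM to 120000 nM.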

Compound 4, solubility: >= 30000 nM
Compound 4 was reported as a limit; the forecaster's own chance of this, stated with the estimate: 80%; the middle value is on the limit's open side.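

Compound 4 also gives only a limit, so no step to it from compound 1, compound 2 or compound 3 can be read: the limit of >= 30000 nM in this assay, at which 4 of the 4 values shown sit.

As far as these compounds go, whether these compounds differ at all in this assay, and by how much, remains open.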